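From benzylamine to aniline: a growth-inhibition estimate

The compounds below may be only part of what the source reports. "The series", "measured", "known", "first", "only" and "open" are said of these compounds alone.

Compound 1 `Cc1ccccc1Nc1nc(NC2CC2)ncc1Cl`: > 100000 nM (a limit of the assay, not a number)
Compound 2 `Cc1ccc(CNc2nc(Nc3ccc(N4CCN(C)CC4)cn3)ncc2Cl)cc1`: 18600 nM

Of the compounds shown here, two have been tested so far in a functional assay on MDA-MB-231 cells (Homo sapiens) for inhibition, read by CCK-8 assay, with a stated time of 48 h; a higher number here means a weaker inhibitor of growth, a lower number a stronger inhibitor of growth. Among the compounds with values here, compound 2 stands alone, giving 18600 nM, the only true number available. The other result is a limit.

Compound 3 `Cc1cccc(Nc2nc(Nc3ccc(N4CCN(C)CC4)cn3)ncc2Cl)c1` has not yet been measured. It carries 3-methylphenyl in place of 4-methylbenzyl on a nitrogen on an aromatic ring. Within the data shown here, no measured step shows what such a change does, so the only guide is compound 2 at 18600 nM. The expected change is a 1.6-fold lower number from compound 2 to compound 3 (0.19 log units; within the scatter), no larger than the usual scatter, and if anything toward stronger inhibition of growth. For compound 3 the estimate in this assay is 12000 nM, with an expected range from 3500 nM to 45000 nM.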

Compound 3, concentration for 50% growth inhibition: 5270 nM
Compound 3: middle estimate off by 2.3-fold (0.36 log units), on the high side; measured number inside the range.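

In this assay, within the data shown here, 3-methylphenyl in place of 4-methylbenzyl on a nitrogen on an aromatic ring gives a 3.5-fold lower number from compound 2 to compound 3 (0.55 log units; beyond the scatter) as the first measured step at this place, showing that the group on this nitrogen can shift the number toward stronger inhibition of growth. The step exchanges one whole group for another, so it cannot show which part of that exchange carries the difference. Nothing shown gives a reason for this step.

On these data alone, whether plain phenyl, 4-methylphenyl or a longer chain ending in an amine on this nitrogen would lower the number further remains open. Among these compounds, compound 1 gives > 100000 nM as a limit of the assay and not a number, and it differs from the other compounds in more than one place, so no step to it can be read.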